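Working notes on compound 4 against compound 3

The source may report more compounds than this note shows. Statements on the series, on what has been measured and on what is new or still open speak of the compounds shown alone.

Measured so far:
compound 1, `Cc1ncc(-c2nc(C(F)(F)F)sc2N2CCN(C(=O)Cn3cnc4cccnc43)[C@H](C)C2)cn1`, 104 nM 
compound 2, `COCCOc1ncc(-c2nc(C(F)(F)F)sc2N2CCN(C(=O)Cn3cnc4cccnc43)[C@H](C)C2)cn1`, 182 nM 
compound 3, `CCOc1ncc(-c2nc(C(F)(F)F)sc2N2CCN(C(=O)Cn3ccc4cccnc43)[C@H](C)C2)cn1`, 47 nM 

All three values come from an assay on blood for inhibition of C-X-C chemokine receptor type 3 (Homo sapiens), with a stated time of 30 min; on this read-out higher numbers stand for weaker inhibition and lower numbers for stronger inhibition. Compound 3 gives the lowest number of the three: compound 1 lies nearest to it and compound 2 furthest away, and both gaps are beyond the scatter. Among the compounds with values here, the only single-site step measured so far is a 1.8-fold higher number from compound 1 to compound 2 (0.24 log units; within the scatter), and it sits on an aromatic carbon, not on the saturated chain carbon bound to a carbonyl carbon that is changed here. Compound 4, `CCOc1ncc(-c2nc(C(F)(F)F)sc2N2CCN(C(=O)Cn3cnc(C(F)(F)F)n3)[C@H](C)C2)cn1`, differs from compound 3 in one place: a group of 9 heavy atoms (3 carbon, 3 nitrogen, 3 fluorine; one five-membered aromatic ring with 3 hetero atoms) in place of a group of 9 heavy atoms (7 carbon, 2 nitrogen; one five-membered aromatic ring with 1 hetero atom, one six-membered aromatic ring with 1 hetero atom), on a saturated chain carbon bound to a carbonyl carbon. Within the data shown here, no measured pair shows a change at that place; compound 1 and compound 3 differ there as well as on the aromatic carbon, so their two values cannot be split into separate steps. Among the measured compounds shown here, the expectation for compound 4 therefore rests on no direct precedent, and the step of a 3.2-fold higher number from compound 3 to compound 4 (0.50 log units; beyond the scatter) is expected with a wide range, leaning toward a higher number. Compound 4 is estimated at 150 nM, with a range from 40 nM to 600 nM.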

Compound 4, half-maximal inhibitory concentration: 524 nM
The estimate for compound 4 lay 3.5-fold (0.54 log units) below the measured number; the range from low to high includes it.
By their numbers in this assay, from the lowest: compound 3; then compounds 1 and 2 (each within the scatter of the next); then compound 4.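

In this assay, the saturated chain carbon bound to a carbonyl carbon now has its first single-site reading, and the change there gives an 11-fold higher number from compound 3 to compound 4 (1.05 log units; beyond the scatter), a large step beyond the scatter. The only earlier single-site step, a 1.8-fold higher number from compound 1 to compound 2 (0.24 log units; within the scatter), stayed within the scatter and sat on an aromatic carbon, so in the compounds shown this chain position is the first site where a single change clearly moves the number. Both groups count 9 heavy atoms, so heavy-atom count alone does not track the step from the two-ring group to 3-(trifluoromethyl)-1H-1,2,4-triazol-1-yl, and no measurement available here accounts for its size.

The compounds shown leave open whether the step belongs to the trifluoromethyl group, to the triazole ring or to the absence of the second ring, a question that a triazole carrying methyl in place of trifluoromethyl, or one carrying a phenyl ring, would help to separate. From the compounds shown here alone, it also remains open whether a step of this size would recur with methyl or 2-methoxyethoxy in place of ethoxy on the aromatic carbon, since this one pair shares the ethoxy group.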